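A few compounds are considered here, and "the series" means these few. Any claim that something is new, unique, unknown or untested is made for them only; others in the source may bear on it.

Compounds measured so far:
compound 1, `CCOC(=O)c1sc2nc(-c3cccs3)cc(-c3ccccc3)c2c1N` — in an assay for inhibition of 15-hydroxyprostaglandin dehydrogenase [NAD(+)] (Homo sapiens), read by fluorescence, with a stated time of 15 min, in the presence of a further agent that is not named here (on this read-out lower numbers stand for stronger inhibition and higher numbers for weaker inhibition), compound 1 gives > 7500 nM
compound 2, `CCCCC(=O)c1sc2nc(-c3cccs3)cc(-c3ccccc3)c2c1N` — in this assay compound 2 gives > 7500 nM

Both of these values are limits of the assay and not numbers. The step from compound 1 to compound 2, butyl in place of ethoxy on a carbonyl carbon, is a step that the two limits leave unreadable from compound 1 to compound 2. Compound 2 therefore stands only at a limit in this assay. The same holds for the other value shown, since (the limit of > 7500 nM in this assay, at which 2 of the 2 values shown sit).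

Compound 3, `CCCCCC[S+]([O-])c1sc2nc(-c3cccs3)cc(-c3ccccc3)c2c1N`, has not yet been measured. It differs from compound 2 by a group of 8 heavy atoms (6 carbon, 1 oxygen, 1 sulfur; no ring) in place of a group of 6 heavy atoms (5 carbon, 1 oxygen; no ring), on an aromatic carbon. Going by the values given here, the only measured step that bears on this change is the one from compound 1 to compound 2, and its size cannot be read. With two limits at the same point, no step beyond the scatter can be expected in this assay in either direction from what is known. Compound 3 is therefore expected to give about 15000 nM, between 5000 nM and 60000 nM. The step that this expectation means is a step that the limit leaves unreadable from compound 2 to compound 3, and the result may again be reported only as a limit.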

Compound 3, half-maximal inhibitory concentration: 18 nM
Compound 3: middle estimate off by 830-fold (2.92 log units), on the high side, outside the stated range (below it).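

Compound 3 shows that the substituent on this aromatic carbon, next to the ring sulfur and next to the ring atom that bears an amino group, can decide the read-out in this assay on the shared core. The group of 8 heavy atoms in place of butylcarbonyl gives an at least 410-fold lower number from compound 2 to compound 3 (2.61 log units; beyond the scatter), and the same group in place of the ester on compound 1 gives an at least 410-fold lower number from compound 1 to compound 3 (2.61 log units; beyond the scatter). The earlier pair could show none of this, and the steps that rest on limits alone cannot be read: the limit of > 7500 nM in this assay, at which 2 of the 3 values shown sit.

The compounds shown leave open whether the sulfur with its oxygen or the longer chain carries this step, as the entering group differs from butylcarbonyl and from the ester in both at once. Going by these compounds, how a butyl chain on the same sulfur, or a carboxylic acid or an amine at this place, would read in this assay also remains open.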